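This account rests on a few compounds, and the source may have more. Where it says the series, first, only, none or still open, it means among the compounds named here.

Measured so far in an assay (strain Wistar) for displacement of a labelled ligand from adenosine receptor A1 (Rattus norvegicus), read by scintillation counting; a lower number here means a stronger inhibitor, a higher number a weaker inhibitor:
compound 1 `COc1ccc(Cl)cc1C(=O)Nc1nc(-c2ccccc2)nc2c1nnn2Cc1ccccc1` gives 7150 nM;
compound 2 `O=C(Nc1nc(-c2ccccc2)nc2c1nnn2Cc1ccccc1)c1ccccc1C(F)(F)F` gives 550 nM;
compound 3 `Nc1nc(-c2ccccc2)nc2c1nnn2Cc1ccccc1` gives 5.6 nM.

Compound 3 stands lowest of the three, beyond the scatter from both others. Compound 4 `O=C(Nc1nc(-c2ccccc2)nc2c1nnn2Cc1ccccc1)c1ccc(Cl)cc1` differs from it by (4-chlorophenyl)carbonyl in place of hydrogen on a nitrogen on an aromatic ring. For the measured compounds named here, two measured steps bear on this. Removing the acyl group altogether gave a 1300-fold lower number from compound 1 to compound 3 (3.11 log units; beyond the scatter), while exchanging one aryl carbonyl for another gave a 13-fold lower number from compound 1 to compound 2 (1.11 log units; beyond the scatter); compound 2 thus shows that an aryl carbonyl on this nitrogen need not cost as much as in compound 1. Compound 4 is therefore expected to sit well above compound 3, with a step of about a 71-fold higher number from compound 3 to compound 4 (1.85 log units; beyond the scatter), giving an estimate of 400 nM in this assay, between 80 nM and 2000 nM.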

Compound 4, inhibition constant: 108 nM
Compound 4: the middle estimate sits 3.7-fold (0.57 log units) above what was measured, within the range that was stated.
By their numbers in this assay, from the lowest: compound 3; then compound 4; then compound 2; then compound 1.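

In this assay, the (4-chlorophenyl)carbonyl group on this nitrogen gives a 19-fold higher number from compound 3 to compound 4 (1.29 log units; beyond the scatter), so this acyl group still carries a large cost. The aryl group on the carbonyl carbon also matters: 4-chlorophenyl gives a 5.1-fold lower number from compound 2 to compound 4 (0.71 log units; beyond the scatter) and a 66-fold lower number from compound 1 to compound 4 (1.82 log units; beyond the scatter). Compound 4 therefore has the lowest number among the three amides, while compound 3, with its free amino group, remains lowest overall. Nothing shown gives a reason for these steps. Still open, going by these compounds, is whether an acetyl group or a longer alkyl chain on this nitrogen would bring the number closer to that of compound 3.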